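The source may report more compounds than this note shows. Statements on the series, on what has been measured and on what is new or still open speak of the compounds shown alone.

Measured in a functional assay (aorta) with Oryctolagus cuniculus as the target; on this read-out lower numbers stand for stronger inhibition and higher numbers for weaker inhibition:
- compound 1 `CC1=NC(C)=C(C(=O)OCCCN2C(=O)c3ccccc3S2(=O)=O)C(c2cccc([N+](=O)[O-])c2)/C1=C(\O)OC(C)C`: 1 nM
- compound 2 `COCCO/C(O)=C1\C(C)=NC(C)=C(C(=O)OCCCN2C(=O)c3ccccc3S2(=O)=O)C1c1cccc([N+](=O)[O-])c1`: 6.8 nM
- compound 3 `CC1=NC(C)=C(C(=O)OCCCN2C(=O)c3ccccc3S2(=O)=O)C(c2cccc([N+](=O)[O-])c2)/C1=C(\O)OCC1CCCO1`: 10.5 nM

Compound 3 stands within the scatter of its nearest neighbour, with a 1.5-fold higher number from compound 2 to compound 3 (0.19 log units; within the scatter). Its furthest neighbour is clearly separated, with an 11-fold higher number from compound 1 to compound 3 (1.02 log units; beyond the scatter).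

The next compound, compound 4 `CC1=NC(C)=C(C(=O)OCCCN2C(=O)c3ccccc3S2(=O)=O)C(c2ccccc2C(F)(F)F)/C1=C(\O)OCC1CCCO1`, carries 2-(trifluoromethyl)phenyl in place of 3-nitrophenyl on a saturated ring carbon. For the measured compounds named here, none of the measured steps touches this place. Those that exist all concern the group on an oxygen on an unsaturated carbon, where a modest change gave a 6.8-fold higher number from compound 1 to compound 2 (0.83 log units; beyond the scatter) and a large one gave an 11-fold higher number from compound 1 to compound 3 (1.02 log units; beyond the scatter). They show that the series can move in this assay, but they do not size this replacement. The expectation therefore stays anchored on compound 3 at 10.5 nM, with no firm step beyond the scatter and only a slight lean towards a higher number. The expected change is a 1.5-fold higher number from compound 3 to compound 4 (0.18 log units; within the scatter). Compound 4 is estimated at 16 nM, with an expected range from 3 nM to 80 nM.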

Compound 4, half-maximal inhibitory concentration: 3.7 nM
Beside the measured number, compound 4's estimate is 4.3-fold (0.64 log units) above it, and the stated range covers the measured number.
By their numbers in this assay, from the lowest: compound 1; then compounds 4, 2 and 3 (each within the scatter of the next, the first and the last beyond it).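

In this assay, for the compounds shown here, the earlier steps all concerned the group on the oxygen, and this is the first to show that the series also responds at the saturated ring carbon: with the (oxolan-2-yl)methyl group held fixed, 2-(trifluoromethyl)phenyl in place of 3-nitrophenyl gives a 2.8-fold lower number from compound 3 to compound 4 (0.45 log units; beyond the scatter). A low number at this place therefore does not depend on the 3-nitrophenyl group. No measurement shown here accounts for this step.

The compounds shown leave open whether the step follows from the trifluoromethyl group itself or from where it sits on the phenyl ring; a 3-(trifluoromethyl)phenyl or a 2-nitrophenyl group would separate the two. Going by these compounds, it also remains open whether the same replacement would give a similar step with isopropyl or 2-methoxyethyl on the oxygen.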